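Trading Carboxy for Hydrogen on the Chain Carbon

A few compounds are considered here, and "the series" means these few. Any claim that something is new, unique, unknown or untested is made for them only; others in the source may bear on it.

Compound 1 `COc1cc(OC)c(NC(=O)Cc2nn(CC(=O)O)c(=O)c3ccccc23)cc1Cl` and compound 2 `COc1cc(OC)c(NC(=O)Cc2cn(CC(=O)O)c3ccccc23)cc1Cl` carry the same amide-linked side chain and differ only in their core. In a functional assay on CHO cells for agonist activity at sphingosine 1-phosphate receptor 2 (Homo sapiens), read by calcium flux (a lower number here means a stronger inhibitor, a higher number a weaker inhibitor), compound 1 reaches only the limit of the assay, > 23300 nM. Compound 2 likewise gives only a limit in this assay, > 23300 nM. Both measured values thus sit at the limit of > 23300 nM in this assay, at which 2 of the 2 values shown sit, so compound 2 stands level with the one other compound shown and no order between them can be read.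

Compound 3 `COc1cc(OC)c(NC(=O)Cc2cn(C)c3ccccc23)cc1Cl` has not yet been measured. It differs from compound 2 by hydrogen in place of carboxy on a saturated chain carbon bound to an aromatic nitrogen. Among the measured compounds shown here, no measured step covers this change. With both measured compounds at the limit, compound 3 is expected to remain weak, an expected step of an at least 1.1-fold lower number from compound 2 to compound 3 (0.06 log units; that floor lies within the scatter). The estimate for compound 3 in this assay is 20000 nM, within 5000 nM to 60000 nM, with a fair chance that only a limit is reported again.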

Compound 3, half-maximal inhibitory concentration in the sphingosine 1-phosphate receptor 2 assay: > 23300 nM
Compound 3: a limit, no number; the forecaster's own chance of this, stated with the estimate: 60%; middle value at least 1.1-fold (0.06 log units) from the limit.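

In the sphingosine 1-phosphate receptor 2 assay compound 3 also gives > 23300 nM and this is only a limit. The step from compound 2 to compound 3 therefore cannot be read. The compounds shown leave open what any of them would actually reach in the sphingosine 1-phosphate receptor 2 assay and whether exchanging carboxymethyl for methyl changes it. In a physicochemical assay for lipophilicity, at pH 7.4 (a lower number here means a more polar compound, a higher number a more lipophilic compound), compound 2 gives 2.13 and compound 3 gives 5.91 and that is a number 3.78 log units higher from compound 2 to compound 3 (beyond the scatter) in this assay.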